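Swapping a butyl for cyclopropylmethyl on the amide nitrogen

The source may hold more compounds than are shown below. What is called first, only, known or untested is meant among the compounds shown, and "the series" means these compounds.

Three compounds share one core and differ only in the group on the amide nitrogen. Compound 1 `CCCN(C(=O)c1ccccc1OCc1ccccc1)[C@@H]1CCC[C@H](N)C1` gives 1230 nM in an assay on HEK293 cells for inhibition of transient receptor potential cation channel subfamily M member 8 (Homo sapiens), read by FLIPR and calcium flux; a higher number here means a weaker inhibitor, a lower number a stronger inhibitor. Compound 2 `N[C@H]1CCC[C@@H](N(C(=O)c2ccccc2OCc2ccccc2)C2CCC2)C1` gives 1360 nM in this assay, and compound 3 `CCCCN(C(=O)c1ccccc1OCc1ccccc1)[C@@H]1CCC[C@H](N)C1` gives 1400 nM. Compound 3 holds the highest of the three numbers, yet all three sit within the scatter of each other. Compound 4 `N[C@H]1CCC[C@@H](N(CC2CC2)C(=O)c2ccccc2OCc2ccccc2)C1` carries the change (cyclopropyl in place of propyl on a saturated chain carbon bound to an amide-type nitrogen). The nearest measured steps, a 1.1-fold higher number from compound 1 to compound 2 (0.04 log units; within the scatter) and a 1.0-fold higher number from compound 2 to compound 3 (0.01 log units; within the scatter), show that trading a chain for a small ring, or back, left the number essentially unchanged. The step of a 1.0-fold lower number from compound 3 to compound 4 (0.02 log units; within the scatter) is therefore expected to stay within the scatter. Compound 4 is estimated at 1350 nM, between 700 nM and 2600 nM.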

Compound 4, half-maximal inhibitory concentration: 593 nM
Compound 4: the middle estimate sits 2.3-fold (0.36 log units) above what was measured; the measured number lies below the stated range.
By their numbers in this assay, from the lowest: compound 4; then compounds 1, 2 and 3 (each within the scatter of the next).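

Of the groups shown on the amide nitrogen, only cyclopropylmethyl moves the number beyond the scatter, and modestly: the change from butyl gives a 2.4-fold lower number from compound 3 to compound 4 (0.37 log units; beyond the scatter) and the change from cyclobutyl gives a 2.3-fold lower number from compound 2 to compound 4 (0.36 log units; beyond the scatter) while the change from propyl gives a 2.1-fold lower number from compound 1 to compound 4 (0.32 log units; beyond the scatter) in each case. The leaving propyl and the entering cyclopropyl hold the same count of carbon, so this step comes with closing a three-membered ring at this place and not with adding carbon. As far as these compounds go, whether cyclobutylmethyl or cyclopentylmethyl on the amide nitrogen would give a lower number stays open. Nothing at hand explains the step.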